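Working notes: one substituent exchanged between compound 2 and compound 3

The compounds below may be only part of what the source reports. "The series", "measured", "known", "first", "only" and "open" are said of these compounds alone.

Two compounds carry a number in a functional assay on HepG2 cells (Homo sapiens) for antiproliferative activity, read by CCK-8 assay, with a stated time of 72 h, tested at 2 uM; on this read-out lower numbers stand for a weaker effect and higher numbers for a stronger effect at the one concentration tested. Compound 1, `Nc1ccccc1NC(=O)c1ccc(Cn2cnc3c(Nc4ccc(-c5ccccn5)cc4)nc(Cl)nc32)cc1`, gives 11.5% in this assay. Compound 2, `CC1CCN(c2nc(Cl)nc3c2ncn3Cc2ccc(C(=O)Nc3ccccc3N)cc2)CC1`, gives 1.22% in this assay and so stands lowest of the two numbers; the nearest, compound 1, lies higher by an amount beyond the usual scatter. For the measured compounds named here, no step between compounds that differ in one place has been measured, so the pair shows only its two values.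

Compound 3, `Nc1ccccc1NC(=O)c1ccc(Cn2cnc3c(Nc4cccc(Cl)c4)nc(Cl)nc32)cc1`, is not yet measured. It differs from compound 2 in one place: (3-chlorophenyl)amino in place of 4-methylpiperidin-1-yl on an aromatic carbon. Nothing measured isolates this exchange. Because compound 1 gives 11.5% with another group at the same place, while compound 2 gives 1.22%, an upward move is expected. The step of a number 6.8 percentage points higher from compound 2 to compound 3 (within the scatter) is expected to be a modest rise in this assay, roughly at the edge of the scatter. Compound 3 is estimated at 8% in this assay, with a range from 0% to 18%.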

Compound 3, a percentage reported as inhibition, at one concentration (the size of the read-out at that concentration, not a potency): 29.9%
Beside the measured number, compound 3's estimate is 21.9 percentage points below it; the whole stated range lies below it.
By their numbers in this assay, from the lowest: compound 2; then compound 1; then compound 3.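

In this assay, (3-chlorophenyl)amino in place of 4-methylpiperidin-1-yl on this aromatic carbon gives a number 28.7 percentage points higher from compound 2 to compound 3 (beyond the scatter), so the read-out at this position can climb well past anything the first two compounds showed. The group on the nitrogen also counts: 3-chlorophenyl in place of 4-(pyridin-2-yl)phenyl gives a number 18.4 percentage points higher from compound 1 to compound 3 (beyond the scatter), and the higher number goes with the 3-chlorophenyl group. No measurement at hand speaks to why either step occurs.

The compounds shown leave open what the chlorine on the 3-chlorophenyl ring contributes, and how an unsubstituted phenyl, or a methoxy group or carboxylic acid in its place, would read. They also leave open whether a simple alkylamine such as cyclopropylamino on the same aromatic carbon would follow the piperidine or the anilines.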